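A few compounds are considered here, and "the series" means these few. Any claim that something is new, unique, unknown or untested is made for them only; others in the source may bear on it.

Measured in a functional assay on MGC-803 cells (Homo sapiens) for inhibition, read by MTT assay, with a stated time of 72 h; a higher number here means a weaker inhibitor, a lower number a stronger inhibitor:

Compound 1 `CCCCc1ccc(NC(=O)C2CCN(C/C=C/c3ccccc3)CC2)cc1`: 2570 nM
Compound 2 `COc1cccc(NC(=O)C2CCN(C/C=C/c3ccccc3)CC2)c1`: 37200 nM
Compound 3 `O=C(Nc1cccc(C(F)(F)F)c1)C1CCN(C/C=C/c2ccccc2)CC1`: 9590 nM

Compound 2, at 37200 nM, carries the highest number of the three and is the weakest inhibitor among them. Compound 4 `O=C(Nc1ccccn1)C1CCN(C/C=C/c2ccccc2)CC1` has not yet been measured. It differs from compound 2 in one place: pyridin-2-yl in place of 3-methoxyphenyl on an amide-type nitrogen. In words, pyridin-2-yl stands in place of 3-methoxyphenyl on an amide-type nitrogen.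

Among the compounds with values here, only one measured step bears on this change, and only loosely. Trifluoromethyl in place of methoxy on an aromatic carbon gave a 3.9-fold lower number from compound 2 to compound 3 (0.59 log units; beyond the scatter), a modest step. Within the data shown here, that swap keeps the carbon-only ring, while compound 4 exchanges the whole group, so no measured step tests this change directly. With compound 2 at the top of the three values, a step no larger than that modest one, toward a lower number, is expected. The expected step is a 1.9-fold lower number from compound 2 to compound 4 (0.27 log units; within the scatter) in this assay. For compound 4 the estimate is 20000 nM, with an expected range of 7000 nM to 60000 nM.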

Compound 4, half-maximal inhibitory concentration: 45200 nM
Beside the measured number, compound 4's estimate is 2.3-fold (0.35 log units) below it; measured number inside the range.
By their numbers in this assay, from the lowest: compound 1; then compound 3; then compounds 2 and 4 (each within the scatter of the next).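

In this assay, replacing the 3-methoxyphenyl group with pyridin-2-yl on the amide-type nitrogen gives a 1.2-fold higher number from compound 2 to compound 4 (0.08 log units; within the scatter), so the two compounds cannot be told apart. This shows that exchanging the whole aromatic group, including a carbon-only ring for one with a ring nitrogen, need not produce a measurable difference at this place, whereas the earlier swap on the ring itself gave a 3.9-fold lower number from compound 2 to compound 3 (0.59 log units; beyond the scatter). No supporting measurement is available to explain this result.

On these data alone, whether an amine or a carboxylic acid attached to the pyridin-2-yl ring would give a number clearly different from that of compound 4 remains open. So does the effect of replacing the ring on the amide-type nitrogen with a longer carbon chain.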